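At the Assay Limit: Compound 3 to Compound 4

The compounds below may be only part of what the source reports. "The series", "measured", "known", "first", "only" and "open" are said of these compounds alone.

Compound 1 `CC(C)[C@H](NC(=O)COc1cccc2ccccc12)C(=O)N[C@@H](CC(=O)O)C(=O)CSc1nc2ccccc2s1`, compound 2 `CC(C)[C@H](NC(=O)COc1cccc2ccccc12)C(=O)N[C@@H](CC(=O)O)C(=O)COc1ccccn1` and compound 3 `CC(C)[C@H](NC(=O)COc1cccc2ccccc12)C(=O)N[C@@H](CC(=O)O)C(=O)COc1ncnc2ccccc12` share one core and differ only in the group on the saturated chain carbon bound to the carbonyl carbon. In a functional assay on Jurkat cells (Homo sapiens) for inhibition (on this read-out higher numbers stand for weaker inhibition and lower numbers for stronger inhibition), compound 1 gives only a limit, > 200000 nM. In this assay compound 2 likewise gives a limit, > 200000 nM. Compound 3 too gives a limit, > 200000 nM. The steps a step that the two limits leave unreadable from compound 1 to compound 2, a step that the two limits leave unreadable from compound 1 to compound 3 and a step that the two limits leave unreadable from compound 2 to compound 3 therefore cannot be sized, since (the limit of > 200000 nM in this assay, at which 3 of the 3 values shown sit). Compound 4 `CC(C)[C@H](NC(=O)COc1cccc2ccccc12)C(=O)N[C@@H](CC(=O)O)C(=O)COn1nnc2ccccc2c1=O` carries a group of 11 heavy atoms (7 carbon, 3 nitrogen, 1 oxygen; one six-membered aromatic ring of carbon only, one six-membered aromatic ring with 3 hetero atoms) in place of a group of 10 heavy atoms (8 carbon, 2 nitrogen; one six-membered aromatic ring of carbon only, one six-membered aromatic ring with 2 hetero atoms), on an oxygen on a saturated carbon. With no readable step among the measured pairs, compound 4 is expected to sit at the same limit, an estimated step of a number no higher from compound 3 to compound 4 (the limit leaves the size open). The estimate for compound 4 is 200000 nM, ranging from 50000 nM to 1000000 nM.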

Compound 4, half-maximal inhibitory concentration: 137000 nM
Estimate against measurement, compound 4: 1.5-fold (0.16 log units) above; the measured number falls inside the stated range.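

Compound 4 is the only one of the four that gives a number rather than a limit in this assay, so this position now has readable steps (an at least 1.4-fold lower number from compound 3 to compound 4 (0.16 log units; that floor lies within the scatter); an at least 1.4-fold lower number from compound 2 to compound 4 (0.16 log units; that floor lies within the scatter); an at least 1.4-fold lower number from compound 1 to compound 4 (0.16 log units; that floor lies within the scatter)). Each floor lies within the scatter, so no real gain in inhibition is established. Compounds 1, 2 and 3 remain at one limit: the limit of > 200000 nM in this assay, at which 3 of the 4 values shown sit.

As far as these compounds go, the true sizes of these steps stay open, as the limits hide where compounds 1, 2 and 3 actually lie. Also open, from the compounds shown here alone, is how an amine or a carboxylic acid at this place would read.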